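Swapping chloro for butoxy on compound 1

The compounds below may be only part of what the source reports. "The series", "measured", "known", "first", "only" and "open" are said of these compounds alone.

In a functional assay on SW620/5-FU cells (Homo sapiens) for cytotoxicity, read by MTT assay, with a stated time of 48 h, in the presence of a further agent that is not named here (on this read-out lower numbers stand for an effect already at smaller amounts and higher numbers for an effect only at larger amounts of compound), compound 1 (`COc1ccc(-c2cc(NNC(=O)Nc3cc(Cl)nc(Cl)c3)nc3c2cnn3C)cc1`) gives 18500 nM. In this assay compound 2 (`CC(C)c1cc(NNC(=O)Nc2cc(Cl)nc(Cl)c2)nc2c1cnn2C`) gives 50100 nM. Of these two, compound 1 has the lower number, so its effect appears at the smaller amount.

Compound 3 (`CCCCOc1cc(NC(=O)NNc2cc(-c3ccc(OC)cc3)c3cnn(C)c3n2)cc(Cl)n1`) has not yet been measured. It differs from compound 1 at one place: butoxy in place of chloro on an aromatic carbon. In short, butoxy takes the place of chloro on an aromatic carbon, next to the ring nitrogen, while the other chloro group remains.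

Among the measured compounds shown here, no measurement yet tests a change at this place. For the measured compounds named here, the only measured step, a 2.7-fold higher number from compound 1 to compound 2 (0.43 log units; beyond the scatter), replaces 4-methoxyphenyl with isopropyl at another place, so it offers only a rough size for one swap and no guide to direction. A modest move either way is possible, but no step beyond the scatter is expected in this assay, and the expectation stays close to compound 1 at 18500 nM. The estimated change is a 1.2-fold lower number from compound 1 to compound 3 (0.09 log units; within the scatter). For compound 3 the estimated value is 15000 nM, with an expected range of 5000 nM to 55000 nM.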

Compound 3, half-maximal effective concentration: 39200 nM
Estimate against measurement, compound 3: 2.6-fold (0.42 log units) below; low and high end bracket the measured number.
By their numbers in this assay, from the lowest: compound 1; then compounds 3 and 2 (each within the scatter of the next).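

Among the compounds shown here, this is the first measurement at this place, on an aromatic carbon next to the ring nitrogen. In this assay, butoxy in place of chloro gives a 2.1-fold higher number from compound 1 to compound 3 (0.33 log units; beyond the scatter), so the position responds to the swap, yet a group of 5 heavy atoms in place of a single chlorine costs only a modest step rather than abolishing the effect. Together with the change at the other place, a 2.7-fold higher number from compound 1 to compound 2 (0.43 log units; beyond the scatter), this leaves compound 1 with the lowest number of the three, as both single changes measured so far raise the number, and nothing here accounts for the rise at the butoxy position.

This one swap removes a chloro group and adds an oxygen-linked chain at the same time, so it remains unclear whether the higher number comes with the loss of chloro, the oxygen or the length of the chain. Ethoxy, a shorter chain, or an amine at this place would help separate these, and it is also open how the remaining chloro group contributes.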